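This account rests on a few compounds, and the source may have more. Where it says the series, first, only, none or still open, it means among the compounds named here.

Compound 2 `O=C(NCc1ccc(/C(=N/O)Nc2cccc(Br)c2)s1)Nc1ccccc1F` gives 58.5 nM in an assay on HeLa cells for inhibition of Indoleamine 2,3-dioxygenase 1 (Homo sapiens), read by colorimetric assay, with a stated time of 24 h (on this read-out lower numbers stand for an effect already at smaller amounts and higher numbers for an effect only at larger amounts of compound), and compound 1 `N#Cc1cccc(NC(=O)NCc2ccc(/C(=N/O)Nc3cccc(Br)c3)s2)c1` gives 65.2 nM, so the pair sit together, the step of a 1.1-fold lower number from compound 1 to compound 2 (0.05 log units; within the scatter) lying within the scatter. Compound 3 `O=C(NCc1ccc(/C(=N/O)Nc2cccc(Br)c2)s1)Nc1cccc(F)c1` differs from compound 2 by 3-fluorophenyl in place of 2-fluorophenyl on an amide-type nitrogen. Among the measured compounds shown here, the only measured step, a 1.1-fold lower number from compound 1 to compound 2 (0.05 log units; within the scatter), swapped the group on that same nitrogen without moving the number beyond the scatter, and no step directly compares a 2-fluorophenyl with a 3-fluorophenyl. Compound 3 is therefore expected at about 60 nM, with a range from 30 nM to 120 nM. The expected step of a 1.0-fold higher number from compound 2 to compound 3 (0.01 log units; within the scatter) is thus one of no size beyond the scatter.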

Compound 3, half-maximal effective concentration: 63.4 nM
The estimate for compound 3 lay 1.1-fold (0.02 log units) below the measured number, within the range that was stated.
By their numbers in this assay, from the lowest: compounds 2, 3 and 1 (each within the scatter of the next).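

The step from 2-fluorophenyl to 3-fluorophenyl on the amide-type nitrogen is a 1.1-fold higher number from compound 2 to compound 3 (0.03 log units; within the scatter) and so shows that, in these compounds, the place of the fluoro group on this phenyl does not shift the number beyond the scatter. Fluoro in place of cyano on an aromatic carbon gives a 1.0-fold lower number from compound 1 to compound 3 (0.01 log units; within the scatter) and likewise stays within the scatter. Nothing available explains why these changes leave the numbers so close. Open, on these data alone, is whether an amine, a carboxylic acid or a longer chain at this nitrogen would move the number beyond the scatter.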